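Working notes on four analogues and a cytotoxicity read-out

This account rests on a few compounds, and the source may have more. Where it says the series, first, only, none or still open, it means among the compounds named here.

Compound 1 `CN(Cc1ccccc1)C(=O)c1ccc(-c2cc(C3=CC(=O)C=CC3=O)no2)s1` is the point of reference. In a functional assay on A549 cells (Homo sapiens) for cytotoxicity, read by XTT assay, with a stated time of 72 h (a higher number here means a weaker inhibitor, a lower number a stronger inhibitor), compound 1 gives > 30000 nM, which is a limit of the assay and not a number. Compound 2 `COc1ccc(OC)c(-c2cc(-c3ccc(C(=O)N(C)Cc4ccccc4)s3)on2)c1` differs from compound 1 by a group of 10 heavy atoms (8 carbon, 2 oxygen; one six-membered aromatic ring of carbon only) in place of a group of 8 heavy atoms (6 carbon, 2 oxygen; one six-membered non-aromatic ring of carbon only), on an aromatic carbon. In this assay compound 2 gives > 30000 nM, again a limit of the assay. The step between them is a step that the two limits leave unreadable from compound 1 to compound 2. Compound 3 `CN(Cc1ccc(F)cc1)C(=O)c1ccc(-c2cc(C3=CC(=O)C=CC3=O)no2)s1` differs from compound 1 by fluoro in place of hydrogen on an aromatic carbon. In this assay compound 3 gives > 30000 nM, also a limit of the assay. That step reads a step that the two limits leave unreadable from compound 1 to compound 3. All three measured values sit at the limit of > 30000 nM in this assay, at which 3 of the 3 values shown sit, so no order among compound 1, compound 2 and compound 3 can be drawn from this read-out.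

Compound 4 `COc1ccc(OC)c(-c2cc(-c3ccc(C(=O)N(C)Cc4ccc(F)cc4)s3)on2)c1` is not yet measured. It differs from compound 3 by a group of 10 heavy atoms (8 carbon, 2 oxygen; one six-membered aromatic ring of carbon only) in place of a group of 8 heavy atoms (6 carbon, 2 oxygen; one six-membered non-aromatic ring of carbon only), on an aromatic carbon. For the measured compounds named here, this is the same change as the one made from compound 1 to compound 2, and the two cores on which it is made differ by fluoro in place of hydrogen on an aromatic carbon. The earlier step stays unreadable because both of its ends sit at the limit of > 30000 nM in this assay, at which 3 of the 3 values shown sit.

The step is expected to be a step that the limit leaves unreadable from compound 3 to compound 4. That expectation rests on compound 1, compound 2 and compound 3 all sitting at the limit of > 30000 nM in this assay, at which 3 of the 3 values shown sit, which leaves no measured movement to build on. Compound 4 is accordingly estimated at 60000 nM, with an expected range from 25000 nM to 200000 nM, and most probably the assay will again report only a limit for compound 4.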

Compound 4, half-maximal inhibitory concentration: > 30000 nM
Compound 4: a limit, no number; the forecaster's own chance of this, stated with the estimate: 85%; the middle value does not contradict the limit.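

In this assay compound 4 gives > 30000 nM and that is a limit of the assay, not a number. The steps to compound 4 from compound 3 and from compound 2 therefore cannot be read, as every value stands at one limit: the limit of > 30000 nM in this assay, at which 4 of the 4 values shown sit.

The compounds shown leave open whether the 2,5-dimethoxyphenyl group or the fluoro group changes cytotoxicity at all on this core.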